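An Amide Swap in a Weakly Antiproliferative Series

This account rests on a few compounds, and the source may have more. Where it says the series, first, only, none or still open, it means among the compounds named here.

Two compounds have so far been measured in a functional assay on A549 cells (Homo sapiens) for antiproliferative activity, read by CCK-8 assay, with a stated time of 48 h; on this read-out lower numbers stand for stronger inhibition and higher numbers for weaker inhibition:

Compound 1 `O=C(Nc1ccccc1)c1cc(Oc2ccc(/C=C/c3ccncc3)cc2)ccn1` gives 79700 nM.
Compound 2 `O=C(Nc1ccc(Cl)cc1)c1cc(Oc2ccc(/C=C/c3ccncc3)cc2)ccn1` gives 62100 nM.

Going by the values given here, compound 2 holds the lower of the two numbers, but the only measured step, a 1.3-fold lower number from compound 1 to compound 2 (0.11 log units; within the scatter), lies within the scatter, so the two compounds cannot be told apart on these data. Both are weak inhibitors of cell growth.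

Compound 3 `COc1ccc(CNC(=O)c2cc(Oc3ccc(/C=C/c4ccncc4)cc3)ccn2)cc1` is not yet measured. It differs from compound 2 in one place: 4-methoxybenzyl in place of 4-chlorophenyl on an amide-type nitrogen. Among the compounds with values here, no measured step covers a change of this kind. Within the data shown here, the single step available concerns a chloro group in place of hydrogen on the same aromatic ring and was itself within the scatter, so it says little about exchanging the whole group on the amide-type nitrogen. Among the measured compounds shown here, since the shared core has given only weak numbers so far, compound 3 is expected to stay in the same region, with a step of about a 1.1-fold lower number from compound 2 to compound 3 (0.05 log units; within the scatter) expected. The estimate for compound 3 is 55000 nM, within a range from 15000 nM to 150000 nM.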

Compound 3, half-maximal inhibitory concentration: 19300 nM
Estimate against measurement, compound 3: 2.8-fold (0.45 log units) above; low and high end bracket the measured number.
By their numbers in this assay, from the lowest: compound 3; then compounds 2 and 1 (each within the scatter of the next).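

Going by these compounds alone, the group on the amide-type nitrogen is the first place where a change moves the number beyond the scatter in this assay: the exchange gives a 3.2-fold lower number from compound 2 to compound 3 (0.51 log units; beyond the scatter), and replacing phenyl with 4-methoxybenzyl gives a 4.1-fold lower number from compound 1 to compound 3 (0.62 log units; beyond the scatter). Both steps are modest, but they show that this position responds to a change of the whole group, which the chloro step alone, a 1.3-fold lower number from compound 1 to compound 2 (0.11 log units; within the scatter), could not show. The new group differs from the old ones in more than one way, since it is larger, carries oxygen, and is a benzyl rather than a phenyl group, and nothing measured here says which of these differences matters.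

The compounds shown leave open whether the methoxy group or the benzyl arrangement accounts for the lower number, a question that plain benzyl, 4-chlorobenzyl and 4-methoxyphenyl on the same nitrogen would separate. They also leave open how far this position can be taken, for example with a longer chain such as 2-phenylethyl or with a group carrying an amine or a carboxylic acid.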